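Hedgehog inhibitors: azole replacement at the chloro-bearing ring

A few compounds are considered here, and "the series" means these few. Any claim that something is new, unique, unknown or untested is made for them only; others in the source may bear on it.

Two compounds of the series have a number in an assay on C3H 10T1/2 cells for inhibition of Sonic hedgehog protein (Mus musculus), read by a luciferase reporter; a higher number here means a weaker inhibitor, a lower number a stronger inhibitor. Compound 1 `Cc1nc(C(F)(F)F)ccc1C(=O)Nc1ccc(Cl)c(-c2nc3c(n2C)CCCC3)c1` carries a bicyclic group on the ring that bears the chloro group and gives 150 nM. Compound 2 `Cc1nc(C(F)(F)F)ccc1C(=O)Nc1ccc(Cl)c(-c2ccn(C)n2)c1` keeps everything except that group, which is replaced by a smaller one, and gives 550 nM; this is the higher of the two numbers. The step of a 3.7-fold higher number from compound 1 to compound 2 (0.56 log units; beyond the scatter) is the only one available and concerns the same attachment point as the change below.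

Compound 3 `Cc1nc(C(F)(F)F)ccc1C(=O)Nc1ccc(Cl)c(-c2ncccn2)c1` is the next member: pyrimidin-2-yl in place of 1-methyl-1H-pyrazol-3-yl on an aromatic carbon. The entering group matches the leaving group in heavy-atom count and acceptor count, so the size change seen from compound 1 to compound 2 does not apply; nothing measured separates a five-membered from a six-membered ring here. The expectation for this assay is therefore a step of a 1.1-fold lower number from compound 2 to compound 3 (0.04 log units; within the scatter), small and not confidently beyond the scatter, with wide uncertainty in both directions. For compound 3 the estimate is 500 nM, with a range from 150 nM to 1800 nM.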

Compound 3, half-maximal inhibitory concentration: 8000 nM
The estimate for compound 3 lay 16-fold (1.20 log units) below the measured number, and the stated range ends below it.
By their numbers in this assay, from the lowest: compound 1; then compound 2; then compound 3.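

In this assay, the position on an aromatic carbon ortho to a chloro group separates two groups that match in heavy-atom count and acceptor count: pyrimidin-2-yl in place of 1-methyl-1H-pyrazol-3-yl gives a 15-fold higher number from compound 2 to compound 3 (1.16 log units; beyond the scatter) and so is a large step, where the earlier change in group size gave the modest 3.7-fold higher number from compound 1 to compound 2 (0.56 log units; beyond the scatter). Heavy-atom count therefore does not order the series at this position, since compound 3 has the same count as compound 2 and the step of a 53-fold higher number from compound 1 to compound 3 (1.73 log units; beyond the scatter) places compound 3 as the weakest of the compounds shown. No supporting measurement bears on why the two groups differ so sharply.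

The compounds shown leave open whether the loss follows from the six-membered ring, from the placing of its ring nitrogens or from the absence of the methyl group on the ring. A 1-methyl-1H-imidazol-2-yl group, a pyridin-2-yl group or a plain phenyl group at this position would begin to separate these readings.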